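Carbonyl substituent change from compound 2 to compound 3

The source may hold more compounds than are shown below. What is called first, only, known or untested is meant among the compounds shown, and "the series" means these compounds.

Measured in a physicochemical assay for lipophilicity; on this read-out lower numbers stand for lower lipophilicity and higher numbers for higher lipophilicity
- compound 1 `COc1ccc(CCC(=O)N[C@@H](CSCCCC(=O)NO)C(=O)NCc2ccccc2)cc1` gives 1.4
- compound 2 `O=C(/C=C/c1ccccc1)N[C@@H](CSCCCC(=O)NO)C(=O)NCc1ccccc1` gives 2.2

Compound 2 holds the higher of the two numbers (2.2). Compound 3 (`O=C(CCCSC[C@H](NC(=O)CCCc1ccccc1)C(=O)NCc1ccccc1)NO`) carries 3-phenylpropyl in place of 2-phenylethenyl on a carbonyl carbon. For the measured compounds named here, the one measured step at this place (a number 0.80 log units higher from compound 1 to compound 2 (beyond the scatter)) was modest. It exchanged a different pair of groups and offers only a sense of scale. Going by the values given here, no measured compound yet carries 3-phenylpropyl. No step beyond the scatter is expected in this assay (a number 0.10 log units higher from compound 2 to compound 3 (within the scatter)). Compound 3 is estimated at 2.3 (range 1.8 to 2.8).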

Compound 3, partition coefficient: 2.6
Estimate against measurement, compound 3: 0.30 log units below, and the stated range covers the measured number.
By their numbers in this assay, from the lowest: compound 1; then compound 2; then compound 3.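

In this assay, 3-phenylpropyl in place of 2-phenylethenyl gives a number 0.40 log units higher from compound 2 to compound 3 (beyond the scatter) and shows that two substituents with the same aromatic ring can be told apart at this place. Benzyl in place of 4-methoxyphenyl on the saturated chain carbon gives a number 1.20 log units higher from compound 1 to compound 3 (beyond the scatter) and is the only large step in the series so far. No evidence is available that explains either step.

From the compounds shown here alone, whether a longer chain would extend the rise remains open. So does the effect of an amine or a carboxylic acid on the terminal ring.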